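Aryl ether variation on the bridged amine series

The source may hold more compounds than are shown below. What is called first, only, known or untested is meant among the compounds shown, and "the series" means these compounds.

Measured so far:
compound 1 `COc1cncc(C2=CC3CC(C2)CN(C)C3)c1` gives 0.6 nM in an in vitro assay on SH-EP1 cells for displacement of a labelled ligand from Neuronal acetylcholine receptor; alpha4/beta2 (Homo sapiens); a lower number here means a stronger inhibitor, a higher number a weaker inhibitor
compound 2 `Clc1ccncc1C1=CC2CNCC(C1)C2` gives 3 nM in this assay
compound 3 `C1=C(c2cncc(OCc3ccccc3)c2)CC2CNCC1C2` gives 0.7 nM in this assay

Compound 3 stands second highest of the three numbers in this assay. Its nearest neighbour is compound 1, whose number is lower by a margin that sits within the scatter, so the two cannot be told apart. The only clear separation is to compound 2, which gives a higher number beyond the scatter.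

The next compound, compound 4 `COc1ccccc1Oc1cncc(C2=CC3CNCC(C2)C3)c1`, keeps the shared core of compound 3 and changes only the group on the ring oxygen: 2-methoxyphenyl in place of benzyl on an oxygen on an aromatic ring. Going by the values given here, both compound 1 and compound 3 show that an oxygen-linked substituent at this position is compatible with a low number, and no measured pair tells how a larger aryl group behaves here. The expectation is therefore a modest step, if any, toward a higher number, with a 2.1-fold higher number from compound 3 to compound 4 (0.33 log units; beyond the scatter) as the estimated step from compound 3 to compound 4. For compound 4 the estimated value in this assay is 1.5 nM, expected between 0.4 nM and 6 nM.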

Compound 4, inhibition constant: 1 nM
Estimate against measurement, compound 4: 1.5-fold (0.18 log units) above; the range from low to high includes it.
By their numbers in this assay, from the lowest: compounds 1, 3 and 4 (each within the scatter of the next); then compound 2.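

In this assay, going by these compounds alone, the change to 2-methoxyphenyl in place of benzyl on an oxygen on an aromatic ring gives a 1.4-fold higher number from compound 3 to compound 4 (0.15 log units; within the scatter) and stays within the scatter, making this the first pair at this position that can be read directly. The oxygen on the aromatic ring therefore carries either benzyl or 2-methoxyphenyl with no separable difference in the number, even though the entering group brings one more heavy atom and a hydrogen-bond acceptor. Nothing given here bears on why the two groups cannot be told apart.

The compounds shown leave open how this assay would read with an amine or a carboxylic acid in place of the oxygen-linked group. They also leave open how plain phenyl on the same oxygen would compare with 2-methoxyphenyl.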